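The source may report more compounds than this note shows. Statements on the series, on what has been measured and on what is new or still open speak of the compounds shown alone.

Measured in a functional assay on MGC-803 cells (Homo sapiens) for antiproliferative activity, read by MTT assay, with a stated time of 72 h; on this read-out lower numbers stand for stronger inhibition and higher numbers for weaker inhibition:
- compound 1 `C/C(=N\NC(=O)c1cccc(S(=O)(=O)N2CCOCC2)c1)c1cc(F)ccc1O`: 2260 nM
- compound 2 `O=C(N/N=C/c1ccco1)c1cccc(S(=O)(=O)N2CCOCC2)c1`: > 100000 nM

The entry for compound 2 is a limit of the assay, not a number, so it stands only at > 100000 nM. Compound 3 `O=C(N/N=C/c1cc(Br)cc(Br)c1O)c1cccc(S(=O)(=O)N2CCOCC2)c1` carries 3,5-dibromo-2-hydroxyphenyl in place of furan-2-yl on a carbon with a double bond to nitrogen. The expectation rests on compound 1, which also has a hydroxy-bearing phenyl group and gives 2260 nM. A large shift toward stronger inhibition in this assay is expected, with an estimated step of an at least 50-fold lower number from compound 2 to compound 3 (1.69 log units; beyond the scatter). The expected value for compound 3 is 2000 nM, with an estimated range of 400 nM to 10000 nM.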

Compound 3, half-maximal inhibitory concentration: 17800 nM
Compound 3: middle estimate off by 8.9-fold (0.95 log units), on the low side, outside the stated range (above it).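

In this assay the change to 3,5-dibromo-2-hydroxyphenyl in place of furan-2-yl on a carbon with a double bond to nitrogen gives an at least 5.6-fold lower number from compound 2 to compound 3 (0.74 log units; beyond the scatter) and turns a limit into a measured value. This position therefore responds to the group placed on it. Going by these compounds, the true size of the step remains unknown, because compound 2 is held only by a limit of the assay: the limit of > 100000 nM in this assay, at which 1 of the 3 values shown sits.

The compounds shown do not separate the hydroxy group from the two bromines. On these data alone, how an unsubstituted phenyl group or an amine would read at this position remains open.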